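This account rests on a few compounds, and the source may have more. Where it says the series, first, only, none or still open, it means among the compounds named here.

Measured so far in a functional assay on HEK293 cells for agonist activity at Vasopressin V2 receptor (Homo sapiens), read by a luciferase reporter and cAMP accumulation; on this read-out lower numbers stand for an effect already at smaller amounts and higher numbers for an effect only at larger amounts of compound:
compound 1 `Cc1cc(C(=O)N2CCCCc3ccccc32)ccc1CNC(=O)Nc1ccccc1F` gives 30 nM
compound 2 `Cc1cc(C(=O)N2CCCCc3ccccc32)ccc1CNC(=O)NCC(=O)O` gives 180 nM

Compound 1 stands at the lowest of the two numbers in this assay. Going by the values given here, its nearest neighbour is compound 2, and the single measured step between them, a 6.0-fold higher number from compound 1 to compound 2 (0.78 log units; beyond the scatter), is modest but beyond the scatter.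

Compound 3 `Cc1cc(C(=O)N2CCCCc3ccccc32)ccc1CNC(=O)N1CCC[C@H]1C(=O)OC(C)(C)C` has not yet been measured in this assay. Against compound 1 it differs in one place:
2-(tert-butoxycarbonyl)pyrrolidin-1-yl in place of (2-fluorophenyl)amino on a carbonyl carbon

Among the compounds with values here, the only measured step that bears on this change is a 6.0-fold higher number from compound 1 to compound 2 (0.78 log units; beyond the scatter): there too the 2-fluorophenyl group and its hydrogen-bond donor left the same carbonyl carbon, and the number rose. Within the data shown here, compound 3 repeats the loss of the aromatic ring and of the donor, but what enters is a five-membered non-aromatic ring carrying a tert-butoxycarbonyl group rather than a carboxymethyl group, and no measured compound carries anything of this kind. A rise in the number is therefore expected, of a size near to or somewhat smaller than the step to compound 2, giving a 3.0-fold higher number from compound 1 to compound 3 (0.48 log units; beyond the scatter). For compound 3 the estimate in this assay is 90 nM, with a range from 30 nM to 300 nM.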

Compound 3, half-maximal effective concentration: 390 nM
For compound 3 the middle estimate is 4.3-fold (0.64 log units) below the measured one, outside the stated range (above it).
By their numbers in this assay, from the lowest: compound 1; then compound 2; then compound 3.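

In this assay the step of a 13-fold higher number from compound 1 to compound 3 (1.11 log units; beyond the scatter) is the largest seen so far at this carbonyl carbon, so the change from (2-fluorophenyl)amino can reach further than the earlier pair showed. The two non-aromatic replacements are also not interchangeable here: the step of a 2.2-fold higher number from compound 2 to compound 3 (0.34 log units; beyond the scatter) is modest but beyond the scatter, and it sets 2-(tert-butoxycarbonyl)pyrrolidin-1-yl apart from (carboxymethyl)amino. No measured evidence at hand explains this order of the three compounds.

The compounds shown do not separate the loss of the aromatic ring, the loss of the hydrogen-bond donor, the pyrrolidine ring and the tert-butyl ester as sources of the rise, nor do they show what the defined stereocentre contributes. A plain pyrrolidin-1-yl group, a free carboxylic acid in place of the tert-butyl ester, the opposite stereoisomer, and a methyl group on the nitrogen of (2-fluorophenyl)amino would each bear on one of these questions.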